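Compound 4: An Expected Solubility Following From Compound 1

The compounds below may be only part of what the source reports. "The series", "measured", "known", "first", "only" and "open" are said of these compounds alone.

Compound 1 `COc1ccc2[nH]c(C(=O)N3CC(=O)N(Cc4ccccc4)[C@@H](CN4CCC5(CC4)CC5)C3)cc2c1`: 28200 nM
Compound 2 `O=C(c1cc2cc(C3CC3)ccc2[nH]1)N1CC(=O)N(Cc2ccccc2)[C@@H](CN2CCN(Cc3ccccc3)CC2)C1`: 12900 nM
Compound 3 `COc1ccc2[nH]c(C(=O)N3CC(=O)N(Cc4ccc[nH]4)[C@@H](Cc4ccccc4)C3)cc2c1`: 38400 nM

Of the compounds shown here, three sharing a common core have been measured in a physicochemical assay for solubility, read by spectrophotometry, in phosphate buffer, with a stated time of 2 h, at pH 7.4; a higher number here means a more soluble compound, a lower number a less soluble compound. Compound 1 stands second highest of the three numbers. Its nearest neighbour is compound 3, whose value lies within the usual scatter of compound 1, so no order between these two can be read from the data. Compound 2 gives the furthest value, lower than compound 1 by a gap that lies beyond the scatter. No pair among these three differs in a single place, so no step between measured compounds is available.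

Compound 4 `COc1ccc2[nH]c(C(=O)N3CC(=O)N(Cc4ccccc4)[C@@H](N4CCc5ccccc54)C3)cc2c1` has not yet been measured in this assay. It differs from compound 1 in one place: a group of 9 heavy atoms (8 carbon, 1 nitrogen; one five-membered non-aromatic ring with 1 hetero atom, one six-membered aromatic ring of carbon only) in place of a group of 9 heavy atoms (8 carbon, 1 nitrogen; one three-membered non-aromatic ring of carbon only, one six-membered non-aromatic ring with 1 hetero atom), on a saturated ring carbon.

For the measured compounds named here, with no measured step to anchor the change, the expectation rests on the three values shown. The group that enters carries a six-membered aromatic ring of carbon only, where the group that leaves carries none. Compound 4 is expected to show a lower number than compound 1, with the step of a 4.0-fold lower number from compound 1 to compound 4 (0.61 log units; beyond the scatter) estimated to lie beyond the scatter. The estimate for compound 4 in this assay is 7000 nM, within a range from 2000 nM to 25000 nM.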

Compound 4, solubility: 7000 nM
Beside the measured number, compound 4's estimate shows no gap at the digits printed; measured number inside the range.
By their numbers in this assay, from the lowest: compounds 4 and 2 (each within the scatter of the next); then compounds 1 and 3 (each within the scatter of the next).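

In this assay the step of a 4.0-fold lower number from compound 1 to compound 4 (0.61 log units; beyond the scatter) is the first single-place comparison among these compounds, and it shows that the number responds to what sits on the saturated ring carbon, next to the ring nitrogen and next to the ring atom that bears a benzyl group. The two groups exchanged there match in heavy atoms, hydrogen-bond donors, hydrogen-bond acceptors and net charge, so those counts do not separate them; what differs is the rings, with 2,3-dihydro-1H-indol-1-yl bringing a five-membered non-aromatic ring and a six-membered aromatic ring of carbon only, in place of a three-membered and a six-membered non-aromatic ring. No measurement shown accounts for the direction or size of this step.

With only this one exchange at the position, the compounds shown leave open whether the six-membered aromatic ring goes with the lower number, a question that a plain piperidine, a morpholine or a phenyl ring there could address. They also leave open whether a carboxylic acid or an open-chain dimethylamino group at the same place would give a number above or below that of compound 1.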